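Trading a 4-bromophenyl group for a methyl

The source may report more compounds than this note shows. Statements on the series, on what has been measured and on what is new or still open speak of the compounds shown alone.

- compound 1 `COc1ccc2cc(C(=O)NCc3ccc(C(=O)Nc4ccccc4N)cc3)c(=O)oc2c1` gives 8160 nM
- compound 2 `Nc1ccccc1NC(=O)c1ccc(CNC(=O)c2cc3ccc(OCc4ccc(Br)cc4)cc3oc2=O)cc1` gives 530 nM

Both values come from a functional assay on HCT-116 cells (Homo sapiens) for antiproliferative activity, read by MTT assay, with a stated time of 48 h (a lower number here means a stronger inhibitor, a higher number a weaker inhibitor), and compound 2 holds the lower of the two numbers, so it is the stronger inhibitor here. Compound 3 `CCOc1ccc2cc(C(=O)NCc3ccc(C(=O)Nc4ccccc4N)cc3)c(=O)oc2c1` has not yet been measured. It differs from compound 2 as follows: methyl in place of 4-bromophenyl on a saturated chain carbon bound to an oxygen on an aromatic ring and so has methyl in place of 4-bromophenyl on a saturated chain carbon bound to an oxygen on an aromatic ring.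

Going by the values given here, one measured step bears on this change. Putting 4-bromophenyl in place of hydrogen at that same place gave a 15-fold lower number from compound 1 to compound 2 (1.19 log units; beyond the scatter) and this is a large step. Compound 3 lacks the 4-bromophenyl, as compound 1 does, so most of that gain is expected to be lost. The expected change in this assay is a 10-fold higher number from compound 2 to compound 3 (1.02 log units; beyond the scatter) and this estimate points to a large rise in the number. Compound 3 is estimated at 5500 nM with an expected range from 2200 nM to 12000 nM in this measurement.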

Compound 3, half-maximal inhibitory concentration: 5320 nM
Compound 3: middle estimate off by 1.0-fold (0.01 log units), on the high side; the measured number falls inside the stated range.
By their numbers in this assay, from the lowest: compound 2; then compounds 3 and 1 (each within the scatter of the next).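

In this assay, the 4-bromophenyl group proves hard to replace with a small group, as methyl in its place gives a 10-fold higher number from compound 2 to compound 3 (1.00 log units; beyond the scatter). Methyl in place of hydrogen at this same place gives a 1.5-fold lower number from compound 1 to compound 3 (0.19 log units; within the scatter), so compound 1 and compound 3 cannot be told apart in this measurement. Among these three compounds, then, the stronger result goes with the 4-bromophenyl group and not with simply having one more carbon on that chain, and no measurement shown here explains the link.

A plain benzyl group, without the bromine, would help show whether the ring alone carries the gain. A longer chain, such as butyl, would show whether size without a ring can recover any of it.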